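The source may report more compounds than this note shows. Statements on the series, on what has been measured and on what is new or still open speak of the compounds shown alone.

Measured so far:
- compound 1 `CC(C)Oc1cc(Oc2cnc(C(=O)N(C)C)nc2)cc(-c2nccc(=O)[nH]2)c1` gives 332000 nM
- compound 2 `CC(C)Oc1cc(Oc2ccc(S(C)(=O)=O)cc2)cc(-c2ncc(Cl)c(=O)[nH]2)c1` gives 24000 nM
- compound 3 `CNS(=O)(=O)c1ccc(Oc2cc(OC(C)C)cc(-c3nccc(=O)[nH]3)c2)cc1` gives 117000 nM

All three values come from a physicochemical assay for solubility, in phosphate buffer, measured as kinetic solubility, with a stated time of 24 h, at pH 6.5; on this read-out lower numbers stand for lower solubility and higher numbers for higher solubility. Compound 1 is the highest of the three, and both compound 3 and compound 2 lie lower by more than the scatter. Compound 4 `C[C@@H](CO)Oc1cc(Oc2cnc(C(=O)N(C)C)nc2)cc(-c2nccc(=O)[nH]2)c1` changes isopropoxy to 1-(hydroxymethyl)ethoxy: hydroxy in place of hydrogen on a saturated chain carbon, two bonds along the chain from an oxygen on an aromatic ring. This places hydroxy in place of hydrogen on a saturated chain carbon, two bonds along the chain from an oxygen on an aromatic ring. Within the data shown here, no measured pair isolates this change, so the expectation rests on the structural change alone. A modest rise is expected, as a 1.4-fold higher number from compound 1 to compound 4 (0.13 log units; within the scatter). For compound 4 the estimated value is 450000 nM, with an expected range of 180000 nM to 1000000 nM.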

Compound 4, solubility: 339000 nM
For compound 4 the middle estimate is 1.3-fold (0.12 log units) above the measured one; the range from low to high includes it.
By their numbers in this assay, from the lowest: compound 2; then compound 3; then compounds 1 and 4 (each within the scatter of the next).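

On this assay the change from isopropoxy to 1-(hydroxymethyl)ethoxy reads as a 1.0-fold higher number from compound 1 to compound 4 (0.01 log units; within the scatter) and does not separate the two compounds. Among these compounds, the earlier compounds all carried isopropoxy, so this is the first reading at this position, and hydroxy on the saturated chain carbon leaves the value within the scatter. Nothing shown bears on why.

As far as these compounds go, whether an amine or a carboxylic acid in place of the hydroxy, or a longer chain, would read the same remains open. So does whether the same change reads alike on the cores of compound 2 and compound 3.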